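The source may report more compounds than this note shows. Statements on the series, on what has been measured and on what is new or still open speak of the compounds shown alone.

Measured compounds:
- compound 1, `CCOC(=O)CN(Cc1ccccc1)c1nc(NCc2cccc(OC)c2)ncc1[N+](=O)[O-]`: 33600 nM
- compound 2, `CCOC(=O)CNc1nc(Nc2ccccc2)ncc1[N+](=O)[O-]`: > 100000 nM

The study measures antiproliferative potency in a functional assay on HepG2 cells (Homo sapiens) for antiproliferative activity, read by MTT assay, with a stated time of 48 h; a lower number here means a stronger inhibitor, a higher number a weaker inhibitor. Compound 1, `CCOC(=O)CN(Cc1ccccc1)c1nc(NCc2cccc(OC)c2)ncc1[N+](=O)[O-]`, gives 33600 nM in this assay. Compound 2, `CCOC(=O)CNc1nc(Nc2ccccc2)ncc1[N+](=O)[O-]`, gives only > 100000 nM, which is a limit of the assay and not a number. Compound 2 therefore stands at the limit of > 100000 nM in this assay, at which 1 of the 2 values shown sits, with no measured potency of its own to compare directly with compound 1.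

Compound 3, `CCOC(=O)CN(Cc1ccccc1)c1nc(Nc2ccccc2)ncc1[N+](=O)[O-]`, differs from compound 2 by benzyl in place of hydrogen on a nitrogen on an aromatic ring. Among the measured compounds shown here, since compound 2 sits at the assay limit, no measured step sets the size of this change. Compound 1, which also carries a benzyl on that nitrogen, reaches a number in this assay, and on that basis compound 3 is expected to move toward a measurable value rather than stay at the limit. The estimated step from compound 2 to compound 3 is an at least 2.0-fold lower number from compound 2 to compound 3 (0.30 log units; that floor lies within the scatter), a gain in potency. Compound 3 is estimated at 50000 nM, within 15000 nM to 150000 nM, with a real chance that this assay again reports only a limit.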

Compound 3, half-maximal inhibitory concentration: 44400 nM
Beside the measured number, compound 3's estimate is 1.1-fold (0.05 log units) above it, and the stated range covers the measured number.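

In this assay, benzyl in place of hydrogen on a nitrogen on an aromatic ring gives an at least 2.2-fold lower number from compound 2 to compound 3 (0.35 log units; beyond the scatter), the first sign of how much this change can move potency at this position. That size is only a floor, as compound 2 stands at a limit of the assay and not at a number: the limit of > 100000 nM in this assay, at which 1 of the 3 values shown sits. With benzyl on that nitrogen in both compounds, phenyl in place of 3-methoxybenzyl on the other nitrogen on an aromatic ring gives a 1.3-fold higher number from compound 1 to compound 3 (0.12 log units; within the scatter), so that second change shows no difference beyond the scatter.

Whether the gain is specific to benzyl stays open, as the compounds shown do not tell how a methyl or a longer chain on that nitrogen would read. They also leave open how a carboxylic acid in place of the ethyl ester would read.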